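Swapping Methyl for Chloro on a Thioether-Linked Benzamide

This account rests on a few compounds, and the source may have more. Where it says the series, first, only, none or still open, it means among the compounds named here.

Compound 1 `Cc1ccc(SCc2ccc(C(=O)Nc3ccccc3N)cc2)cc1` is the starting point. In a functional assay on SMMC-7721 cells (Homo sapiens) for inhibition, read by CCK-8 assay, with a stated time of 72 h, tested at 2 uM (a higher number here means more inhibition of growth at the concentration tested, a lower number less inhibition of growth), compound 1 gives 25.1%, the highest of the three numbers measured. Compound 3 `CC(C)(C)c1ccc(SCc2ccc(/C=C/C(=O)Nc3ccccc3N)cc2)cc1` gives 18.3%, a result that lies within the scatter of compound 1, while compound 2 `Nc1ccccc1NC(=O)/C=C/c1ccc(CSc2cccc(F)c2)cc1` gives 8.56%, which lies beyond the scatter below compound 1.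

The new compound is compound 4 `Nc1ccccc1NC(=O)c1ccc(CSc2ccc(Cl)cc2)cc1`. It differs from compound 1 in a single place: chloro in place of methyl on an aromatic carbon The change sits on an aromatic carbon of a six-membered aromatic ring of carbon only, para to a large group, so that (4-methylphenyl)sulfanyl becomes (4-chlorophenyl)sulfanyl.

Going by the values given here, only one measured step touches the same ring on the sulfur: a number 9.7 percentage points higher from compound 2 to compound 3 (within the scatter), where the group on the sulfur changed from 3-fluorophenyl to 4-(tert-butyl)phenyl. That is a larger alteration than the present one, made in compounds that differ from compound 1 elsewhere as well, yet it moved the number only within the scatter. A small exchange of chloro for methyl is therefore expected to leave this assay roughly where it stands, with no step beyond the scatter: the expected step is a number 3.1 percentage points lower from compound 1 to compound 4 (within the scatter). Compound 4 is estimated at 22%, with a range from 10% to 34%.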

Compound 4, percent growth inhibition at one concentration: 2.93%
For compound 4 the middle estimate is 19.1 percentage points above the measured one; the measured number lies below the stated range.
By their numbers in this assay, from the lowest: compounds 4, 2, 3 and 1 (each within the scatter of the next, the first and the last beyond it).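

The step of a number 22.2 percentage points lower from compound 1 to compound 4 (beyond the scatter) in this assay shows that this place on the aromatic ring, para to a large group, is sensitive to change: one heavy atom replaced by one heavy atom, with no ring, hydrogen-bond donor, hydrogen-bond acceptor or net charge entering or leaving, is enough to move the number beyond the scatter. The earlier step on the group attached to the sulfur, a number 9.7 percentage points higher from compound 2 to compound 3 (within the scatter), stayed within the scatter even though it altered that group far more, so the size of a change on this ring does not by itself tell how far the number will move. No measurement shown here accounts for the difference between methyl and chloro at this place.

With only methyl and chloro shown at this place on the core of compound 1, it remains open whether a methoxy group, an amine or a carboxylic acid there would give a number nearer to compound 1 or to compound 4. On these data alone, it also remains open whether chloro in the same place would lower the number in the core of compound 3, which carries a different linker to the amide.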